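Trifluoromethyl on the pendant phenyl of compound 1

The source may hold more compounds than are shown below. What is called first, only, known or untested is meant among the compounds shown, and "the series" means these compounds.

Among the measured compounds shown here, compound 1 `CC(C)(CCCCOc1cc(-c2ccccc2)c2ccccc2n1)C(=O)O` stands lowest of the two numbers so far: in an assay on membranes from spleen (Cavia porcellus) for binding affinity to leukotriene B4 receptor 1 (Homo sapiens) (on this read-out lower numbers stand for stronger inhibition and higher numbers for weaker inhibition), compound 1 gives 183 nM. Compound 2 `CC(CCCCOc1cc(-c2ccccc2)c2ccccc2n1)C(=O)O` gives 550 nM in this assay, the step being a 3.0-fold higher number from compound 1 to compound 2 (0.48 log units; beyond the scatter); that step concerns only the chain methyl. Compound 3 `CC(C)(CCCCOc1cc(-c2ccc(C(F)(F)F)cc2)c2ccccc2n1)C(=O)O` differs from compound 1 by trifluoromethyl in place of hydrogen on an aromatic carbon. For the measured compounds named here, no measured step touches the aromatic ring, so nothing here bears directly on the change, and no step beyond the scatter is expected in this assay. Compound 3 is therefore estimated at 170 nM, range 50 nM to 600 nM, meaning an expected step of a 1.1-fold lower number from compound 1 to compound 3 (0.03 log units; within the scatter).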

Compound 3, half-maximal inhibitory concentration: 300 nM
Beside the measured number, compound 3's estimate is 1.8-fold (0.25 log units) below it; low and high end bracket the measured number.
By their numbers in this assay, from the lowest: compounds 1, 3 and 2 (each within the scatter of the next, the first and the last beyond it).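

In this assay the change to 4-(trifluoromethyl)phenyl gives a 1.6-fold higher number from compound 1 to compound 3 (0.21 log units; within the scatter) and thus no step beyond the scatter, so this position on the pendant phenyl, para to a large group, accepts trifluoromethyl with affinity held in the range of compound 1. Among the compounds shown here, this is the first reading on the aromatic ring, as the earlier step concerned only the chain methyl. No measured evidence accounts for this result.

Going by these compounds, whether a smaller fluorine, a methoxy or an amine at this position would also leave the number within the scatter remains open. Also open, on these data alone, is whether trifluoromethyl would give a similar step on the scaffold of compound 2, which lacks the chain methyl.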